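Methoxy addition on the hydroxyphenyl hydrazone series

The compounds below may be only part of what the source reports. "The series", "measured", "known", "first", "only" and "open" are said of these compounds alone.

Within the data shown here, compound 2 `Oc1ccccc1/C=N/Nc1cnc2ccccc2n1` stands at the lower of the two numbers so far: in a functional assay on HL-60 cells (Homo sapiens) for inhibition, read by MTT assay (on this read-out higher numbers stand for weaker inhibition and lower numbers for stronger inhibition), compound 2 gives 819 nM. Compound 1 `O=[N+]([O-])c1ccc(O)c(/C=N/Nc2cnc3ccccc3n2)c1` gives 1750 nM in this assay. Among the measured compounds shown here, the single measured step is a 2.1-fold lower number from compound 1 to compound 2 (0.33 log units; beyond the scatter). Compound 3 `COc1ccc(/C=N/Nc2cnc3ccccc3n2)c(O)c1` is not yet measured; it differs from compound 2 by methoxy in place of hydrogen on an aromatic carbon. For the measured compounds named here, that one measured step concerns a nitro group leaving, a different kind of change, so it does not bear directly on a methoxy entering in compound 3, and no measured pair shows what a methoxy does here. With nothing to anchor a shift in either direction, the expected step of a 1.2-fold lower number from compound 2 to compound 3 (0.07 log units; within the scatter) is small and most likely within the scatter. For compound 3 the estimate in this assay is 700 nM, with a range from 250 nM to 2000 nM.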

Compound 3, half-maximal inhibitory concentration: 4190 nM
Estimate against measurement, compound 3: 6.0-fold (0.78 log units) below, outside the stated range (above it).
By their numbers in this assay, from the lowest: compound 2; then compound 1; then compound 3.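

In this assay, methoxy in place of hydrogen, meta to a hydroxy group and para to a large group, gives a 5.1-fold higher number from compound 2 to compound 3 (0.71 log units; beyond the scatter), so this ring position does not tolerate this change without a shift in the read-out. Among these compounds, this is the first measured entry of a group on the ring, and it moves the number upward, the same direction as the nitro-bearing compound 1 relative to compound 2, where hydrogen in place of nitro gives a 2.1-fold lower number from compound 1 to compound 2 (0.33 log units; beyond the scatter). Nothing measured explains the rise with methoxy.

Going by these compounds, whether the rise belongs to methoxy itself or to any group at this position stays open, and a methyl group, fluorine or an amine at the same carbon would separate the two. The compounds shown also leave open how methoxy behaves on the other ring carbons.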